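The source may report more compounds than this note shows. Statements on the series, on what has been measured and on what is new or still open speak of the compounds shown alone.

The measured compounds in a functional assay on EC9706 cells (Homo sapiens) for cytotoxicity, read by MTT assay, with a stated time of 48 h (on this read-out lower numbers stand for stronger inhibition and higher numbers for weaker inhibition), are these:

Compound 1, `COC(OC)C1OC(C)(C)OC1Cc1cnc2ccc([N+](=O)[O-])cc2n1`, gives 69.2 ug/mL.
Compound 2, `COC(OC)C1OC(C)(C)OC1Cc1cnc2cc(Cl)ccc2n1`, gives 30.5 ug/mL.
Compound 3, `COC(OC)C1OC(C)(C)OC1Cc1cnc2cc(C(=O)c3ccccc3)ccc2n1`, gives 80 ug/mL.

On these numbers compound 1 stands second highest of the three. Its nearest neighbour is compound 3, whose value sits within the usual scatter of that of compound 1, so the two cannot be told apart on this read-out. Compound 2 lies furthest away, with a number clearly lower than that of compound 1, beyond the scatter.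

The step to the unmeasured compound 4, `COC(OC)C1OC(C)(C)OC1Cc1cnc2ccc(C(=O)c3ccccc3)cc2n1`, is benzoyl in place of nitro on an aromatic carbon. For the measured compounds named here, one measured step bears on this change, though not exactly: a 2.6-fold higher number from compound 2 to compound 3 (0.42 log units; beyond the scatter). There the benzoyl entered in place of chloro, and at a different place on the ring, so the carry-over to a benzoyl replacing nitro is uncertain. Compound 3, which already carries a benzoyl, sits within the scatter of compound 1, which weighs against any large movement.

Taking both together, the expected step is a 1.3-fold higher number from compound 1 to compound 4 (0.11 log units; within the scatter), a drift toward a higher number that may well stay within the scatter. The estimate for compound 4 in this assay is therefore 90 ug/mL, with a range from 45 ug/mL to 180 ug/mL.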

Compound 4, half-maximal inhibitory concentration: 80 ug/mL
Estimate against measurement, compound 4: 1.1-fold (0.05 log units) above; the measured number falls inside the stated range.
By their numbers in this assay, from the lowest: compound 2; then compounds 1, 3 and 4 (each within the scatter of the next).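

In this assay, the exchange of nitro for benzoyl on this aromatic carbon, meta to a fused ring and para to a fused ring, gives a 1.2-fold higher number from compound 1 to compound 4 (0.06 log units; within the scatter), so a group of 8 heavy atoms with an aromatic ring of its own can replace one of 3 heavy atoms without a change that can be told apart on this read-out. The earlier step had shown benzoyl only against chloro and at another place on the ring, whereas here compound 3 gives 80 ug/mL and compound 4, with the benzoyl at this position, gives 80 ug/mL, the same printed number. Nothing among the available data accounts for this tolerance of the benzoyl in place of nitro.

Compound 2 gives 30.5 ug/mL. Still open, on these data alone, is whether a chloro on this carbon would give a number like that one, or whether such a number holds only at the place where compound 2 carries its chloro. Also open, as far as these compounds go, is whether an amine or a carboxylic acid on this carbon would stand apart from nitro and benzoyl beyond the scatter.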